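The source may hold more compounds than are shown below. What is called first, only, known or untested is meant among the compounds shown, and "the series" means these compounds.

Measured in a functional assay on HeLa cells (Homo sapiens) for antiproliferative activity, read by MTT assay, with a stated time of 48 h; on this read-out higher numbers stand for weaker inhibition and lower numbers for stronger inhibition:
Compound 1 `COc1ccc2c(/C=C/C(=O)c3cc(OC)c(OC)c(SC)c3)c[nH]c2c1`: 131 nM
Compound 2 `COc1ccc2c(/C=C(\C)C(=O)c3cc(OC)c(OC)c([Se]C)c3)cn(C)c2c1`: 32 nM

Of these two compounds, compound 1 has the higher number and so the weaker inhibition: compound 1 stands at 131 nM, while compound 2 gives 32 nM, a gap beyond the usual scatter. Within the data shown here, the two differ in more than one place, and no measured pair isolates a single change.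

Compound 3 `COc1ccc2c(/C=C/C(=O)c3cc(OC)c(OC)c([N+](=O)[O-])c3)c[nH]c2c1` keeps the core of compound 1 but has nitro in place of methylsulfanyl on an aromatic carbon, ortho to a methoxy group (nitro in place of methylsulfanyl on an aromatic carbon). Neither measured compound carries a nitro group, so the data do not show directly what this replacement does. The expectation therefore rests on the structural change alone and remains uncertain. A moderate step towards weaker inhibition is expected in this assay, although a step within the scatter cannot be ruled out. The estimated step is a 3.1-fold higher number from compound 1 to compound 3 (0.48 log units; beyond the scatter). For compound 3, the expected value is 400 nM, with an estimated range of 100 nM to 2000 nM.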

Compound 3, half-maximal inhibitory concentration: 850 nM
Estimate against measurement, compound 3: 2.1-fold (0.33 log units) below, and the stated range covers the measured number.
By their numbers in this assay, from the lowest: compound 2; then compound 1; then compound 3.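

In this assay, among these compounds, putting nitro in place of methylsulfanyl on this aromatic carbon, ortho to a methoxy group, gives a 6.5-fold higher number from compound 1 to compound 3 (0.81 log units; beyond the scatter), the only step here that isolates a single change. This shows that inhibition at this position depends on which of these two groups is present, and that with the rest of compound 1 unchanged, methylsulfanyl gives the stronger inhibition of the pair. No measured finding is available to explain the difference between methylsulfanyl and nitro at this position.

The compounds shown leave open how an amine, a carboxylic acid or a longer chain such as ethylsulfanyl would behave on the same aromatic carbon, and so whether the step seen here belongs to nitro in particular or would recur with other replacements of methylsulfanyl. They also leave the contributions within compound 2 unresolved, since it differs from compound 1 in more than one place and no single change on the way between them can be read from these compounds.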